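The compounds below may be only part of what the source reports. "The series", "measured", "known", "first", "only" and "open" are said of these compounds alone.

Measured compounds in a functional assay on A-375 cells (Homo sapiens) for antiproliferative activity, read by CCK-8 assay, with a stated time of 72 h, tested at 2 uM; on this read-out lower numbers stand for a weaker effect and higher numbers for a stronger effect at the one concentration tested:
Compound 1 `Nc1ccccc1NC(=O)c1ccc(CSC(=S)N2CCN(Cc3ccccn3)CC2)cc1` gives 20.7%.
Compound 2 `Nc1ccccc1NC(=O)c1ccc(CSC(=S)N2CCN(c3ccc(Cl)cc3)CC2)cc1` gives 32.2%.
Compound 3 `Nc1ccccc1NC(=O)c1ccc(CSC(=S)N2CCN(Cc3cccnc3)CC2)cc1` gives 31.5%.

Compound 3 stands close beside compound 2 on these numbers, since a number 0.7 percentage points lower from compound 2 to compound 3 (within the scatter), and it stands clearly apart from compound 1, since a number 10.8 percentage points higher from compound 1 to compound 3 (beyond the scatter). The remaining measured step, a number 11.5 percentage points higher from compound 1 to compound 2 (beyond the scatter), shows the same spread between compound 1 and the other two.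

Compound 4 `Nc1ccccc1NC(=O)c1ccc(CSC(=S)N2CCN(c3cnccn3)CC2)cc1` differs from compound 3 in one place: pyrazin-2-yl in place of (pyridin-3-yl)methyl on an amine nitrogen in a ring. The step from compound 2 to compound 3 is the only measured one that bears on this change, as it also exchanges a group on the same ring nitrogen, and it stayed within the scatter. Going by the values given here, no measured step exchanges one heteroaromatic ring for another directly on that nitrogen, so the direction is open. For compound 4 the expected step is therefore a number 1.5 percentage points lower from compound 3 to compound 4 (within the scatter), none beyond the scatter. Compound 4 is estimated to give 30% in this assay, expected to lie between 15% and 45%.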

Compound 4, a percentage reported as inhibition, at one concentration (the size of the read-out at that concentration, not a potency): 29.1%
For compound 4 the middle estimate is 0.9 percentage points above the measured one; measured number inside the range.
By their numbers in this assay, from the lowest: compounds 1, 4, 3 and 2 (each within the scatter of the next, the first and the last beyond it).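

In this assay pyrazin-2-yl, with its six-membered aromatic ring bearing 2 hetero atoms, is tolerated on the amine nitrogen in a ring about as well as the groups it is compared with: the read-out shows a number 2.4 percentage points lower from compound 3 to compound 4 (within the scatter) and a number 3.1 percentage points lower from compound 2 to compound 4 (within the scatter). Going by these compounds alone, compound 1 had stood clearly apart from compounds 2 and 3, but the step to pyrazin-2-yl, a number 8.4 percentage points higher from compound 1 to compound 4 (within the scatter), is the first from compound 1 to stay within the scatter. No measurement shown here accounts for these steps.

The compounds shown leave open whether a simple ethyl chain or an acetyl group on the same nitrogen would give a read-out in this range. They also leave open how the compounds compare in potency, since each is represented by its effect at one concentration.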